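Swapping an amide for an ether on the amine arm

The source may hold more compounds than are shown below. What is called first, only, known or untested is meant among the compounds shown, and "the series" means these compounds.

Measured so far:
compound 1, `O=C1CN=C(NC[C@@H]2CCCc3cc(S(=O)(=O)c4cccc(F)c4)ccc32)N1`, 0.1 nM
compound 2, `O=C(NC[C@@H]1CCCc2cc(S(=O)(=O)c3cccc(F)c3)ccc21)c1ccc[nH]1`, 5.01 nM
compound 3, `NC(=O)CNC[C@@H]1CCCc2cc(S(=O)(=O)c3cccc(F)c3)ccc21`, 0.1 nM

In an assay on isolated protein for displacement of a labelled ligand from 5-hydroxytryptamine receptor 6 (Homo sapiens) (a lower number here means a stronger inhibitor, a higher number a weaker inhibitor), compound 3 stands level with compound 1 and far from compound 2, which shows a 50-fold lower number from compound 2 to compound 3 (1.70 log units; beyond the scatter). Compound 4, `COCCNC[C@@H]1CCCc2cc(S(=O)(=O)c3cccc(F)c3)ccc21`, differs from compound 3 by methoxymethyl in place of carbamoyl on a saturated chain carbon bound to an amine nitrogen. The amine nitrogen itself stays, as it does in compound 1 and compound 3; only compound 2 turns it into an amide, and that is where the large change appears, as a 50-fold higher number from compound 1 to compound 2 (1.70 log units; beyond the scatter). Going by the values given here, no measured step removes a carbamoyl group, so the bearing of the measured steps is indirect. The expected change is a 3.0-fold higher number from compound 3 to compound 4 (0.48 log units; beyond the scatter), a small loss at most. Compound 4 is estimated at 0.3 nM, within 0.08 nM to 2 nM.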

Compound 4, inhibition constant: 0.251 nM
Beside the measured number, compound 4's estimate is 1.2-fold (0.08 log units) above it; the range from low to high includes it.
By their numbers in this assay, from the lowest: compounds 1 and 3 (each within the scatter of the next); then compound 4; then compound 2.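

In this assay, the step to the ether costs little, at a 2.5-fold higher number from compound 3 to compound 4 (0.40 log units; beyond the scatter), even though the hydrogen-bond donor counted for carbamoyl is gone, so that donor is not required for a low number at this position. The ring-bearing group of compound 1 gives a similar result (a 2.5-fold higher number from compound 1 to compound 4 (0.40 log units; beyond the scatter)), which shows that neither a ring nor a carbonyl on this arm is needed. Compound 4 also stays far from the amide compound 2 (a 20-fold lower number from compound 2 to compound 4 (1.30 log units; beyond the scatter)), so the simple 2-methoxyethyl chain keeps most of the strength.

As far as these compounds go, how a longer chain, a carboxylic acid or a terminal amine would behave at this place remains open. No supporting data are available to explain the modest loss.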